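The source may hold more compounds than are shown below. What is called first, only, known or untested is meant among the compounds shown, and "the series" means these compounds.

Measured compounds:
Compound 1, `Cc1cc(CN(CC2CC2)C(CC(=O)O)c2ccc(Cl)cc2)ccc1OCCN1C(=O)CCC1=O` — 65 nM
Compound 2, `Cc1cc(CN(CC2CCCC2)C(CC(=O)O)c2ccc(Cl)cc2)ccc1OCCN1C(=O)CCC1=O` — 71 nM

In an assay on CHO cells for displacement of a labelled ligand from C-X-C chemokine receptor type 3 (Homo sapiens), with a stated time of 60 min (on this read-out lower numbers stand for stronger inhibition and higher numbers for weaker inhibition), compound 1 gives 65 nM, and compound 2 gives 71 nM. Going by the values given here, of these two numbers, compound 2 holds the second, but the only step between them, a 1.1-fold higher number from compound 1 to compound 2 (0.04 log units; within the scatter), lies within the scatter, so the two compounds cannot be told apart on this read-out.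

Compound 3, `Cc1cc(CN(CC2CCCCC2)C(CC(=O)O)c2ccc(Cl)cc2)ccc1OCCN1C(=O)CCC1=O`, is not yet measured. It differs from compound 2 in one place: cyclohexyl in place of cyclopentyl on a saturated chain carbon bound to an amine nitrogen. Among the compounds with values here, the one step that bears on this change is the earlier enlargement of the ring at the same place, a 1.1-fold higher number from compound 1 to compound 2 (0.04 log units; within the scatter), which produced no shift beyond the scatter. Going one ring size further is therefore expected to do little as well: the expected step of a 1.1-fold higher number from compound 2 to compound 3 (0.02 log units; within the scatter) is one of no change beyond the scatter. Compound 3 is thus estimated at 75 nM, with a range from 35 nM to 160 nM.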

Compound 3, half-maximal inhibitory concentration: 81 nM
Estimate against measurement, compound 3: 1.1-fold (0.03 log units) below; measured number inside the range.
By their numbers in this assay, from the lowest: compounds 1, 2 and 3 (each within the scatter of the next).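

Cyclohexyl in place of cyclopentyl, on a saturated chain carbon bound to an amine nitrogen, gives a 1.1-fold higher number from compound 2 to compound 3 (0.06 log units; within the scatter) in this assay. The widest comparison available at this place, cyclohexyl in place of cyclopropyl, gives a 1.2-fold higher number from compound 1 to compound 3 (0.10 log units; within the scatter), so even the two ends of this series of carbon-only rings cannot be told apart on this read-out. No measurement at hand explains why these three rings give such similar numbers.

The compounds shown carry only carbon rings at this place, so they leave open what a ring holding an amine, such as piperidinyl, or a carboxylic acid on the ring would do. They also leave open whether a larger ring, such as cycloheptyl, or an open longer chain would stay within the scatter.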